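Solubility notes: aromatic ring for cyclohexyl on the shared core

A few compounds are considered here, and "the series" means these few. Any claim that something is new, unique, unknown or untested is made for them only; others in the source may bear on it.

The series shares one core, carried in compound 1 `CNC(=O)c1cc(C(=O)NC2CC2)cn(Cc2cccc3cc[nH]c23)c1=O`, compound 2 `CNC(=O)c1cc(C(=O)NC2CC2)cn(Cc2nccc3[nH]ccc23)c1=O` and compound 3 `CNC(=O)c1cc(C(=O)NC2CC2)cn(CC2CCCCC2)c1=O`. In a physicochemical assay for solubility (a higher number here means a more soluble compound, a lower number a less soluble compound), compound 3 reaches a limit, >= 148 ug/mL. Compound 1 also reaches a limit in this assay, >= 144 ug/mL. Among the compounds with values here, compound 2 is the only member with a number, and in this assay compound 2 gives 73 ug/mL. The step of an at least 2.0-fold higher number from compound 2 to compound 3 (0.30 log units; that floor lies within the scatter) is read against a limit, and the step that the two limits leave unreadable from compound 1 to compound 3 runs between two limits and cannot be sized; the limit of >= 144 ug/mL in this assay, at which 1 of the 3 values shown sits, and the limit of >= 148 ug/mL in this assay, at which 1 of the 3 values shown sits, mark where those limits sit.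

Compound 4 `CNC(=O)c1cc(C(=O)NC2CC2)cn(Cc2cccc(C)c2)c1=O` differs from compound 3 by 3-methylphenyl in place of cyclohexyl on a saturated chain carbon bound to an aromatic nitrogen. Within the data shown here, no measured step swaps cyclohexyl for an aromatic carbon ring on that carbon; the nearest evidence is compound 1, whose 1H-indol-7-yl group also sits at a limit, and the step of an at least 2.0-fold higher number from compound 2 to compound 3 (0.30 log units; that floor lies within the scatter). The step expected here, an at least 1.2-fold lower number from compound 3 to compound 4 (0.09 log units; that floor lies within the scatter), is small, with a fair chance that only a limit is returned. For compound 4 the value in this assay is estimated at 120 ug/mL, with a range from 50 ug/mL to 200 ug/mL.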

Compound 4, solubility: >= 205 ug/mL
Compound 4 was reported as a limit (the forecaster's own chance of this, stated with the estimate: 45%); at least 1.7-fold (0.23 log units) between middle value and limit.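

Compound 4 places an aromatic carbon ring on the saturated chain carbon bound to an aromatic nitrogen, and in this assay its result is again a limit, not a number: the limit of >= 205 ug/mL in this assay, at which 1 of the 4 values shown sits. Within the data shown here, the one readable step is an at least 2.8-fold higher number from compound 2 to compound 4 (0.44 log units; beyond the scatter), the first step to clear the scatter, and it is a floor rather than a measured size. The steps to compound 4 from compound 1 and from compound 3 run between two limits and cannot be read, so the change from cyclohexylmethyl to 3-methylbenzyl has no size here.

From the compounds shown here alone, the true values of compound 1, compound 3 and compound 4 remain open. Going by these compounds, it is also open whether a carboxylic acid or an amine in place of 3-methylphenyl on that carbon would give a limit or a number.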